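The source may report more compounds than this note shows. Statements on the series, on what has been measured and on what is new or still open speak of the compounds shown alone.

Of the compounds shown here, three have been measured in a physicochemical assay for lipophilicity, at pH 7.4 (a higher number here means a more lipophilic compound, a lower number a more polar compound), and none of them has yielded an exact number. Compound 2, `Cc1cc(N[C@H](CCCCNCc2ccccc2F)C(=O)NO)cc(C)c1F`, gives < 3, which is a limit of the assay and not a number. Compound 1, `Cc1cc(S(=O)(=O)NCCCC[C@@H](Nc2cc(C)c(F)c(C)c2)C(=O)NO)ccc1F`, gives < 3, also a limit. Compound 3, `Cc1ccc(CNCCCC[C@@H](Nc2cc(C)c(F)c(C)c2)C(=O)NO)cc1`, gives < 3, again a limit. The exact place of compound 2 on this scale is therefore unknown.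

Compound 4, `Cc1cc(N[C@H](CCCCNCc2ccc(C(F)(F)F)cc2)C(=O)NO)cc(C)c1F`, carries 4-(trifluoromethyl)phenyl in place of 2-fluorophenyl on a saturated chain carbon bound to an amine nitrogen. For the measured compounds named here, the one measured step at this place is a step that the two limits leave unreadable from compound 2 to compound 3, so it offers no size to carry over. The remaining guide is the limit of < 3 in this assay, at which 3 of the 3 values shown sit, and compound 4 is expected to be reported as a limit too. On these data alone, no change beyond the usual scatter can be expected with confidence, and the direction stays open. The expected change is a step that the limit leaves unreadable from compound 2 to compound 4. For compound 4, the estimate in this assay is 2.5, with an expected range from 1.8 to 3.2.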

Compound 4, distribution coefficient: < 3
Compound 4 ended at the assay's limit; the forecaster's own chance of this, stated with the estimate: 80%; the middle value lies beyond the limit too.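

No step can be read between compound 2, compound 3 and compound 4, because each result is a limit of the assay and not a number: the limit of < 3 in this assay, at which 4 of the 4 values shown sit. The compounds shown leave open where each one actually lies in this assay, and whether exchanging these groups changes that value at all.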